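The compounds below may be only part of what the source reports. "The series", "measured", "known", "first", "only" and "open" are said of these compounds alone.

Three measured compounds share a core and were tested in a functional assay on PC-3 cells (Homo sapiens) for cytotoxicity, read by MTT assay; a lower number here means a stronger inhibitor, a higher number a weaker inhibitor. Compound 1 `COc1ccc2cc([C@H](C)c3nnc(SCc4c(C)cc(C)cc4C)n3-c3cccc(Cl)c3)ccc2c1` gives 16300 nM in this assay. Compound 2 `COc1ccc2cc([C@H](C)c3nnc(SCc4c(Cl)cccc4Cl)n3-c3cccc(Cl)c3)ccc2c1` gives 165000 nM, and compound 3 `COc1ccc2cc([C@H](C)c3nnc(SCc4c(Cl)cccc4Cl)n3-c3ccc(F)cc3)ccc2c1` gives 216000 nM. Compound 2 and compound 3 sit within the scatter of each other, with a 1.3-fold higher number from compound 2 to compound 3 (0.12 log units; within the scatter); the difference between their cores is 4-fluorophenyl in place of 3-chlorophenyl on an aromatic nitrogen. Compound 1, by contrast, stands well apart from compound 2: there is a 10-fold lower number from compound 2 to compound 1 (1.01 log units; beyond the scatter), a step that lies beyond the scatter, and the structural change behind it is 2,4,6-trimethylphenyl in place of 2,6-dichlorophenyl on a saturated chain carbon bound to a sulfur.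

Compound 4 `COc1ccc2cc([C@H](C)c3nnc(SCc4c(C)cc(C)cc4C)n3-c3ccc(F)cc3)ccc2c1` has not yet been measured in this assay. Among the compounds with values here, it differs from compound 3 by 2,4,6-trimethylphenyl in place of 2,6-dichlorophenyl on a saturated chain carbon bound to a sulfur, which is the same change, at the same place, as the one that separates compound 2 from compound 1. Among the compounds shown this change occurs twice in all, once measured and once not. The expectation for the step from compound 3 to compound 4 in this assay is an 8.6-fold lower number from compound 3 to compound 4 (0.94 log units; beyond the scatter), which rests on the step of a 10-fold lower number from compound 2 to compound 1 (1.01 log units; beyond the scatter) and on the closeness shown by a 1.3-fold higher number from compound 2 to compound 3 (0.12 log units; within the scatter). On that basis compound 4 is estimated at 25000 nM in this assay, expected to fall between 8000 nM and 80000 nM.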

Compound 4, half-maximal inhibitory concentration: 43300 nM
For compound 4 the middle estimate is 1.7-fold (0.24 log units) below the measured one; the range from low to high includes it.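

Putting 2,4,6-trimethylphenyl in place of 2,6-dichlorophenyl on a saturated chain carbon bound to a sulfur again lowers the number in this assay, with a 5.0-fold lower number from compound 3 to compound 4 (0.70 log units; beyond the scatter), and the size of this step agrees with that of the earlier one: the same change on two cores in this assay, a 10-fold lower number (1.01 log units; beyond the scatter) from compound 2 to compound 1 and a 5.0-fold lower number (0.70 log units; beyond the scatter) from compound 3 to compound 4, 2.0-fold (0.31 log units) apart, within the scatter of two such steps. The other change, 4-fluorophenyl in place of 3-chlorophenyl on an aromatic nitrogen, now gives a 2.7-fold higher number from compound 1 to compound 4 (0.42 log units; beyond the scatter); this step is beyond the scatter while its earlier counterpart was within it, yet the two steps do not differ beyond what such pairs allow: the same change on two cores in this assay, a 1.3-fold higher number (0.12 log units; within the scatter) from compound 2 to compound 3 and a 2.7-fold higher number (0.42 log units; beyond the scatter) from compound 1 to compound 4, 2.0-fold (0.31 log units) apart, within the scatter of two such steps. Within these four compounds, then, each change carries from one core to the other, but with only two readings per change this does not show that either would carry to further cores, and it gives no reason for the shift in the number.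

The compounds shown leave open what a longer alkyl chain, or a benzyl group bearing an amine or a carboxylic acid, would do in place of the 2,4,6-trimethylbenzyl group. They also leave open how an unsubstituted phenyl or a pyridine on the aromatic nitrogen would behave alongside either benzyl group.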